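Stereocentre flip on the tert-butyl ester side chain

A few compounds are considered here, and "the series" means these few. Any claim that something is new, unique, unknown or untested is made for them only; others in the source may bear on it.

Compounds measured: compound 1 `Cc1ccc(CNC(=O)c2[nH]cnc2C(=O)Nc2ccc(Cl)c(Cl)c2)cc1`, 15200 nM; compound 2 `C[C@H](NC(=O)c1[nH]cnc1C(=O)Nc1ccc(Cl)c(Cl)c1)c1ccccc1`, 5900 nM; compound 3 `C[C@@H](NC(=O)c1[nH]cnc1C(=O)Nc1ccc(Cl)c(Cl)c1)C(=O)OC(C)(C)C`, 2500 nM.

In a functional assay on HL-60 cells (Homo sapiens), with a stated time of 4 days (on this read-out lower numbers stand for stronger inhibition and higher numbers for weaker inhibition), compound 1 gives the highest of the three numbers. The steps of a 2.6-fold lower number from compound 1 to compound 2 (0.41 log units; beyond the scatter) and a 6.1-fold lower number from compound 1 to compound 3 (0.78 log units; beyond the scatter) both run downward, and a 2.4-fold lower number from compound 2 to compound 3 (0.37 log units; beyond the scatter) runs the same way. Compound 4 `C[C@H](NC(=O)c1[nH]cnc1C(=O)Nc1ccc(Cl)c(Cl)c1)C(=O)OC(C)(C)C` differs from compound 1 as follows: 1-(tert-butoxycarbonyl)ethyl in place of 4-methylbenzyl on an amide-type nitrogen. Compound 3 carries the same group with the stereocentre drawn the other way, so the step of a 6.1-fold lower number from compound 1 to compound 3 (0.78 log units; beyond the scatter) bears most directly on compound 4, though how the configuration matters is not shown. Compound 4 is therefore expected to give 3500 nM, within 1200 nM to 10000 nM, a step of a 4.3-fold lower number from compound 1 to compound 4 (0.64 log units; beyond the scatter).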

Compound 4, half-maximal inhibitory concentration: 2400 nM
Beside the measured number, compound 4's estimate is 1.5-fold (0.16 log units) above it; measured number inside the range.
By their numbers in this assay, from the lowest: compounds 4 and 3 (each within the scatter of the next); then compound 2; then compound 1.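

In this assay, the configuration at the saturated chain carbon on the amide-type nitrogen makes no readable difference, with a 1.0-fold lower number from compound 3 to compound 4 (0.02 log units; within the scatter). The drawn S form keeps the advantage of the tert-butoxycarbonyl series, with a 6.3-fold lower number from compound 1 to compound 4 (0.80 log units; beyond the scatter) and a 2.5-fold lower number from compound 2 to compound 4 (0.39 log units; beyond the scatter), and this advantage therefore does not depend on one configuration. The stereochemical comparison stands on a single change: the fact that compounds 3 and 4 differ only in the configuration as drawn

Going by these compounds, whether a carboxylic acid or a primary amide in place of the tert-butoxycarbonyl group would hold these numbers remains open. The same holds for a longer chain in place of the methyl on that carbon.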